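The source may hold more compounds than are shown below. What is called first, only, known or untested is meant among the compounds shown, and "the series" means these compounds.

Series notes on a functional assay on A-375 cells (Homo sapiens) for antiproliferative activity, read by trypan blue exclusion, with a stated time of 48 h, tested at 10 uM; on this read-out lower numbers stand for a stronger effect and higher numbers for a weaker effect at the one concentration tested.

Measured so far:
compound 1, `CC(=O)Nc1nc(-c2cccc(NS(=O)(=O)c3ccc(C#CCO)cc3)c2)cs1`, gives 48.8%
compound 2, `C#Cc1ccc(S(=O)(=O)Nc2cccc(-c3csc(NC(C)=O)n3)c2)cc1`, gives 1.2%

Compound 2 stands as the lower of the two numbers, the stronger effect on this read-out, with compound 1 the nearest and well beyond the scatter: a number 47.6 percentage points lower from compound 1 to compound 2 (beyond the scatter), hydrogen in place of hydroxymethyl on a triple-bonded carbon. Compound 3, `CCCCCCCCC#Cc1ccc(S(=O)(=O)Nc2cccc(-c3csc(NC(C)=O)n3)c2)cc1`, keeps the core of compound 2 and differs only in octyl in place of hydrogen on a triple-bonded carbon. Going by the values given here, the one step that bears on this position is the step from compound 1 to compound 2, which shows that what sits on that carbon can shift the number by a large amount. Among the compounds with values here, no measured pair shows octyl there, so the direction is open; since compound 2 already sits near the bottom of the scale, the number for compound 3 can scarcely fall further and is expected to rise somewhat, a number 16.8 percentage points higher from compound 2 to compound 3 (beyond the scatter). The estimate for compound 3 is 18%, within 1% to 55%.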

Compound 3, a percentage reported as activity, at one concentration (the size of the read-out at that concentration, not a potency): < 1%
Compound 3 was reported as a limit (the forecaster's own chance of this, stated with the estimate: 0%); middle value at least 17 percentage points from the limit.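

In this assay compound 3 is reported at a limit of the assay, not at a number: the limit of < 1% in this assay, at which 1 of the 3 values shown sits. A substituent on the triple-bonded carbon does not in itself bring the weaker number seen for compound 1, since the octyl chain leaves the two compounds unseparated, a number at least 0.2 percentage points lower from compound 2 to compound 3 (that floor lies within the scatter). Set against the hydroxymethyl compound, the step is large, a number at least 47.8 percentage points lower from compound 1 to compound 3 (beyond the scatter), so among the compounds shown the weak number goes only with the chain that ends in hydroxy, and not with a chain on this carbon as such.

On these data alone, how a propyl chain, or a chain longer than octyl, would read at this position remains open. Also open, as far as these compounds go, is whether an amine or a carboxylic acid at the chain end would read like the hydroxy compound or like the octyl compound.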